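The source may report more compounds than this note shows. Statements on the series, on what has been measured and on what is new or still open speak of the compounds shown alone.

Working notes on the series, read in a functional assay on K562 cells (Homo sapiens) for cytotoxicity, with a stated time of 72 h (on this read-out lower numbers stand for stronger inhibition and higher numbers for weaker inhibition), throughout. Compound 1 (`Cc1cc(-c2c(-c3cccc(C)n3)nn3c2C(C)C(C)(C)C3)ccn1`) gives > 100000 nM here, which is a limit of the assay and not a number. Compound 2 (`Cc1cccc(-c2nn3c(c2-c2ccnc(Cl)c2)CC(C)(C)C3)n1`) gives > 100000 nM here, again a limit. Compound 1 therefore has no exact position in the series and stands at the limit of > 100000 nM in this assay, at which 2 of the 2 values shown sit, with no number to compare.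

Compound 3 (`Cc1cccc(-c2nn3c(c2-c2ccncc2)C(C)C(C)(C)C3)n1`) departs from compound 1 in one place, (hydrogen in place of methyl on an aromatic carbon), and the same difference reads 2-methylpyridin-4-yl to pyridin-4-yl. Here hydrogen replaces methyl on an aromatic carbon, next to the ring nitrogen. Among the measured compounds shown here, no measured pair isolates this change, so its size has to be judged without a direct precedent.

The expectation for this assay is no shift beyond the scatter, in either direction. The expected step is a number no higher from compound 1 to compound 3 (the limit leaves the size open) on this estimate. This expectation rests on compound 1 with its limit of > 100000 nM as the only starting point. For compound 3 the estimated value is 100000 nM with an expected range from 30000 nM to 300000 nM and a limit is the likeliest report.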

Compound 3, half-maximal inhibitory concentration: > 100000 nM
Compound 3: only a limit was reported; the forecaster's own chance of this, stated with the estimate: 85%; the middle value lies on the limit itself.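

In this assay compound 3 gives > 100000 nM, a limit of the assay and not a number. With compound 1 also at a limit, no step can be read between compound 1 and compound 3. The compounds shown leave open how any of them ranks against the others, since all stand at one limit: the limit of > 100000 nM in this assay, at which 3 of the 3 values shown sit.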